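Swapping a Fluorophenyl for a Methylphenyl: Cytotoxicity Outlook

The source may hold more compounds than are shown below. What is called first, only, known or untested is meant among the compounds shown, and "the series" means these compounds.

Compound 1 `O=C(c1ccc2c(c1)OCCO2)C1CCN(Cc2coc(-c3ccc(Br)cc3)n2)CC1` in an ADME assay on HEK293 cells (Homo sapiens) for cytotoxicity, read by MTT assay, with a stated time of 36 h (on this read-out lower numbers stand for stronger inhibition and higher numbers for weaker inhibition), gives > 150 ug/mL, a limit of the assay.
Compound 2 `O=C(c1ccc2c(c1)OCCO2)C1CCN(Cc2coc(-c3ccccc3F)n2)CC1` in this assay gives > 150 ug/mL, a limit.
Compound 3 `O=C(c1ccc2c(c1)OCCO2)C1CCN(Cc2coc(-c3cccc(F)c3)n2)CC1` in this assay gives > 150 ug/mL, a limit.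

Compound 3 thus stands only at a limit, and the other two values do the same, all sitting at the limit of > 150 ug/mL in this assay, at which 3 of the 3 values shown sit. Compound 4 `Cc1ccc(-c2nc(CN3CCC(C(=O)c4ccc5c(c4)OCCO5)CC3)co2)cc1` differs from compound 3 by 4-methylphenyl in place of 3-fluorophenyl on an aromatic carbon. The steps a step that the two limits leave unreadable from compound 1 to compound 2, a step that the two limits leave unreadable from compound 1 to compound 3 and a step that the two limits leave unreadable from compound 2 to compound 3 bear on this change, yet their size is unreadable from two limits. Within the data shown here, no measured step points to a change beyond the scatter, so the step from compound 3 to compound 4 is expected to be a number no higher from compound 3 to compound 4 (the limit leaves the size open). Compound 4 is expected to give 150 ug/mL in this assay, most likely again as a limit, within 100 ug/mL to 300 ug/mL.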

Compound 4, half-maximal inhibitory concentration: > 150 ug/mL
Compound 4: a limit, no number; the forecaster's own chance of this, stated with the estimate: 85%; the middle value lies on the limit itself.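

Among these compounds, compound 1, compound 2, compound 3 and compound 4 all give only a limit, so no step among them can be read. From the compounds shown here alone, what stays open is how these compounds compare in this assay as actual numbers rather than limits.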